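The source may report more compounds than this note shows. Statements on the series, on what has been measured and on what is new or still open speak of the compounds shown alone.

Measured compounds:
- compound 1, `CS(=O)(=O)c1ccc(CSc2nc(-c3ccc(F)cc3)c(-c3ccncc3)[nH]2)cc1`, in a functional assay (Homo sapiens) for inhibition; on this read-out higher numbers stand for weaker inhibition and lower numbers for stronger inhibition: 330 nM
- compound 2, `CS(=O)(=O)c1ccc(CSc2nc(-c3ccc(Br)cc3)c(-c3ccncc3)[nH]2)cc1`: 640 nM
- compound 3, `CS(=O)(=O)c1ccc(CSc2nc(-c3ccccc3)c(-c3ccncc3)[nH]2)cc1`: 1700 nM

Compound 1 gives the lowest number of the three. Its nearest neighbour is compound 2, with a 1.9-fold higher number from compound 1 to compound 2 (0.29 log units; within the scatter), a step inside the scatter, so the two cannot be ranked against each other. Compound 3 stands furthest away, with a 5.2-fold higher number from compound 1 to compound 3 (0.71 log units; beyond the scatter), and compound 2 to compound 3 shows a 2.7-fold higher number from compound 2 to compound 3 (0.42 log units; beyond the scatter).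

Compound 4 is `C[S+]([O-])c1cc(CSc2nc(-c3ccc(F)cc3)c(-c3ccncc3)[nH]2)ccc1O`. Relative to compound 1 the change is a group of 10 heavy atoms (7 carbon, 2 oxygen, 1 sulfur; one six-membered aromatic ring of carbon only) in place of a group of 10 heavy atoms (7 carbon, 2 oxygen, 1 sulfur; one six-membered aromatic ring of carbon only), on a saturated chain carbon bound to a sulfur. The three measured steps all concern the substituent on the other aromatic ring and leave the group on the saturated chain carbon bound to a sulfur untouched, so none of them bears directly on this change. Within the data shown here, the data therefore give no measured precedent for the step, and the expectation rests on the shared core alone: compound 4 is expected to stay in the range of the measured set, with a 1.5-fold higher number from compound 1 to compound 4 (0.18 log units; within the scatter) as the estimated step, which may lie within the scatter. The estimate for compound 4 in this assay is 500 nM, within 120 nM to 2500 nM.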

Compound 4, half-maximal inhibitory concentration: 2300 nM
Compound 4: the middle estimate sits 4.6-fold (0.66 log units) below what was measured, within the range that was stated.
By their numbers in this assay, from the lowest: compounds 1 and 2 (each within the scatter of the next); then compounds 3 and 4 (each within the scatter of the next).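

In this assay, replacing the 4-(methylsulfonyl)phenyl group on the saturated chain carbon bound to a sulfur with a group of the same atoms, joined differently, gives a 7.0-fold higher number from compound 1 to compound 4 (0.84 log units; beyond the scatter). Among these compounds, this is the first measured sign that the group at this place matters, as the earlier steps concerned only the substituent on the other aromatic ring, and here the read-out shifts beyond the scatter with no change in the atoms present. Nothing measured here explains the step.

The compounds shown leave open which part of the rearrangement carries the step, since the entering group differs from the 4-(methylsulfonyl)phenyl group in more than one respect, including its 1 hydrogen-bond donor. They also leave open how an amine or a carboxylic acid on this aromatic ring would read in this assay.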